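A few compounds are considered here, and "the series" means these few. Any claim that something is new, unique, unknown or untested is made for them only; others in the source may bear on it.

Compound 1 `Oc1cc(-c2ccc(Cl)cc2)nc2ncccc12`, compound 2 `COc1cccc(-c2cc(O)c3c(C)cc(C)nc3n2)c1` and compound 3 `Cc1ccnc2nc(-c3ccc(Cl)cc3)cc(O)c12` share a fused two-ring core carrying a hydroxyl and an aryl group. In a functional assay on 786-0 cells (Homo sapiens) (a lower number here means a stronger inhibitor of growth, a higher number a weaker inhibitor of growth), compound 1 gives 33900 nM, compound 3 gives 3980 nM, and compound 2 gives 437 nM. Compound 3 and compound 1 differ in one place, (hydrogen in place of methyl on an aromatic carbon), and that change made a step of an 8.5-fold higher number from compound 3 to compound 1 (0.93 log units; beyond the scatter). How the core of compound 2 differs from that of compound 3 is not broken down here.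

Compound 4 `COc1cccc(-c2cc(O)c3c(C)ccnc3n2)c1` is not yet measured. It differs from compound 2 by hydrogen in place of methyl on an aromatic carbon. This is the same kind of change as from compound 3 to compound 1, but not the same: there the methyl sat ortho to a fused ring, meta to a fused ring and opposite the ring nitrogen, whereas here it sits next to the ring nitrogen, meta to a fused ring, meta to a methyl group and para to a fused ring. Because the earlier step was an 8.5-fold higher number from compound 3 to compound 1 (0.93 log units; beyond the scatter), a weakening in the same direction is expected, though smaller and less certain given the different place. Compound 4 is therefore expected to give 1800 nM in this assay, between 600 nM and 6000 nM, a step of a 4.1-fold higher number from compound 2 to compound 4 (0.61 log units; beyond the scatter).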

Compound 4, concentration for 50% growth inhibition: 51.3 nM
Compound 4: the middle estimate sits 35-fold (1.55 log units) above what was measured, and the stated range ends above it.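

Putting hydrogen in place of methyl on an aromatic carbon gave an 8.5-fold lower number from compound 2 to compound 4 (0.93 log units; beyond the scatter) in this assay. The direction of this change therefore did not carry over from one core to the other, and the two steps run opposite ways: the same change on two cores in this assay, an 8.5-fold higher number (0.93 log units; beyond the scatter) from compound 3 to compound 1 and an 8.5-fold lower number (0.93 log units; beyond the scatter) from compound 2 to compound 4, 73-fold (1.86 log units) apart, beyond the scatter of two such steps This does not show why they differ, since the methyl that leaves sits in a different place in each pair and the pairs also carry different aryl groups, and two pairs give no rule for other cores in this series.

The compounds shown leave open how an ethyl group, a chlorine atom or an amine would compare with hydrogen at that place in compound 4. They also leave open what taking away the methyl group that remains on compound 4 would do.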